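Swapping Isopropyl for Benzyl on the Ether Oxygen

The source may report more compounds than this note shows. Statements on the series, on what has been measured and on what is new or still open speak of the compounds shown alone.

Compound 1 `Cc1[nH]c(=O)n(C)c1-c1ccc(OC(C)C)cc1`: 20400 nM
Compound 2 `CCCCCCCCCCCOc1ccc(-c2c(C)[nH]c(=O)n2C)cc1`: 9700 nM
Compound 3 `Cc1[nH]c(=O)n(C2CCCCC2)c1-c1ccc(OC(C)C)cc1`: 13000 nM

In a functional assay on brain (Rattus norvegicus, strain Wistar) for inhibition (a higher number here means a weaker inhibitor, a lower number a stronger inhibitor), compound 3 sits second highest of the three numbers shown, though within the scatter of both compound 2 and compound 1. Compound 4 `Cc1[nH]c(=O)n(C2CCCCC2)c1-c1ccc(OCc2ccccc2)cc1` differs from compound 3 by benzyl in place of isopropyl on an oxygen on an aromatic ring. Among the compounds with values here, the one measured step, a 1.6-fold lower number from compound 1 to compound 3 (0.20 log units; within the scatter), concerns the aromatic nitrogen, not this oxygen, and stayed within the scatter. Compound 1 gives 20400 nM and compound 2 gives 9700 nM; these two differ only at the oxygen on the aromatic ring and also lie within the scatter of each other. A step of a 1.6-fold lower number from compound 3 to compound 4 (0.21 log units; within the scatter) is therefore expected for compound 4, small and inside the scatter. Compound 4 is estimated at 8000 nM, between 2500 nM and 25000 nM.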

Compound 4, half-maximal inhibitory concentration: 8300 nM
Compound 4: middle estimate off by 1.0-fold (0.02 log units), on the low side, within the range that was stated.
By their numbers in this assay, from the lowest: compounds 4, 2, 3 and 1 (each within the scatter of the next, the first and the last beyond it).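

In this assay, benzyl in place of isopropyl on an oxygen on an aromatic ring gives a 1.6-fold lower number from compound 3 to compound 4 (0.19 log units; within the scatter), with the cyclohexyl on the aromatic nitrogen unchanged. This oxygen therefore carries either isopropoxy or benzyloxy, with its added six-membered aromatic ring, without a difference that stands clear of the scatter. No measurement shown bears on the reason for this result. As far as these compounds go, whether the same swap would read alike with methyl on the aromatic nitrogen stays open. So does whether an amine or a carboxylic acid on this oxygen would give a step beyond the scatter.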